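This account rests on a few compounds, and the source may have more. Where it says the series, first, only, none or still open, it means among the compounds named here.

In a functional assay on THP-1 cells (Homo sapiens) for antiproliferative activity, tested at 100 uM (on this read-out higher numbers stand for a stronger effect at the one concentration tested and lower numbers for a weaker effect), compound 1 `COC(=O)c1ccc(OC)c(S(=O)(=O)Nc2ccc3c(c2)cc(C)c(=O)n3C)c1` gives 102%, the highest of the three numbers recorded. Compound 2 `CC(=O)Oc1ccc(CONC(=O)c2ccc(CS(=O)(=O)Nc3ccc4cc(C)c(=O)n(C)c4c3)cc2)cc1` gives 91% in this assay, a number that lies beyond the scatter below compound 1. Compound 3 `Cc1cc2cc(NS(=O)(=O)c3ccc(C(=O)NO)cc3)ccc2n(C)c1=O`, which also carries a hydroxycarbamoyl group, gives 78% in this assay, the lowest of the three and again beyond the scatter from compound 1.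

Compound 4 `COc1ccc(C(=O)NO)cc1S(=O)(=O)Nc1ccc2c(c1)cc(C)c(=O)n2C` has not yet been measured in this assay. It differs from compound 1 in a single place: hydroxyamino in place of methoxy on a carbonyl carbon

Among the compounds with values here, no measured pair shows this exact change, so its size has to be judged from what the three compounds show. The expectation is a modest downward step from compound 1 to compound 4, close to the edge of the scatter, because compound 3 with the same hydroxycarbamoyl group gives 78%. The step of a number 14 percentage points lower from compound 1 to compound 4 (beyond the scatter) is the estimate for that move. Compound 4 is therefore expected to give about 88% in this assay, within a range from 70% to 100%.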

Compound 4, a percentage reported as inhibition, at one concentration (the size of the read-out at that concentration, not a potency): 43%
Beside the measured number, compound 4's estimate is 45 percentage points above it, outside the stated range (below it).
By their numbers in this assay, from the lowest: compound 4; then compound 3; then compound 2; then compound 1.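

In this assay, within the data shown here, the change from methoxycarbonyl to hydroxycarbamoyl on the core of compound 1 gives the first comparison at a single place, and it reads as a number 59 percentage points lower from compound 1 to compound 4 (beyond the scatter). The three earlier compounds differ from one another in more than one place, so none of them could show what this exchange alone does; on this carbonyl carbon, hydroxyamino in place of methoxy proves to be far from a neutral exchange. Nothing available here accounts for the size of this step.

As far as these compounds go, whether an amine or a hydroxyl on the same carbonyl carbon, the latter giving a carboxylic acid, would stay near compound 1 or fall near compound 4 remains open. Also open, from the compounds shown here alone, is whether the same exchange would give a step of similar size on another scaffold.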